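This account rests on a few compounds, and the source may have more. Where it says the series, first, only, none or still open, it means among the compounds named here.

Measured so far:
Compound 1 `COc1cc2c(c(O)c1C(=O)/C=C/c1ccc(OC(=O)c3cccc(Cl)c3)cc1)CCC(C)(C)O2` — in an assay on HEK293T cells for inhibition of nuclear factor NF-kappa-B complex (Homo sapiens), read by a luciferase reporter (a higher number here means a weaker inhibitor, a lower number a stronger inhibitor), compound 1 gives > 30000 nM, a limit of the assay rather than a number.
Compound 2 `COc1cc2c(c(O)c1C(=O)/C=C/c1ccc(OC(=O)c3ccc(Cl)nc3)cc1)CCC(C)(C)O2` — in this assay compound 2 gives > 30000 nM, again a limit of the assay.
Compound 3 `CCCCC(=O)Oc1ccc(/C=C/C(=O)c2c(OC)cc3c(c2O)CCC(C)(C)O3)cc1` — in this assay compound 3 gives > 30000 nM, also a limit of the assay.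

Compound 2 therefore stands at the same limit as every other value shown, since (the limit of > 30000 nM in this assay, at which 3 of the 3 values shown sit). The steps among the measured compounds, a step that the two limits leave unreadable from compound 1 to compound 2, a step that the two limits leave unreadable from compound 1 to compound 3 and a step that the two limits leave unreadable from compound 2 to compound 3, cannot be read in size. Each of them runs between two limits.

The next compound, compound 4 `COc1cc2c(c(O)c1C(=O)/C=C/c1ccc(OC(=O)c3cccc(Br)c3)cc1)CCC(C)(C)O2`, differs from compound 2 in one place: 3-bromophenyl in place of 6-chloropyridin-3-yl on a carbonyl carbon. The three measured steps bear on this change only in showing that swapping the group on that carbonyl carbon has never moved a compound away from the limit. No size of step can be expected beyond that, and the step that the limit leaves unreadable from compound 2 to compound 4 is estimated to leave compound 4 at the limit as well. Compound 4 is therefore expected to give 40000 nM in this assay, within a range of 15000 nM to 100000 nM.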

Compound 4, half-maximal inhibitory concentration: > 30000 nM
Compound 4: only a limit was reported; the forecaster's own chance of this, stated with the estimate: 85%; the middle value lies beyond the limit too.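

No step from compound 4 to compound 1, compound 2 or compound 3 can be read in size, because all four compounds sit at one limit: the limit of > 30000 nM in this assay, at which 4 of the 4 values shown sit.

The compounds shown leave open whether any group on that carbonyl carbon can give a real number in this assay.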